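Changing the Ring on the Aromatic Nitrogen

This account rests on a few compounds, and the source may have more. Where it says the series, first, only, none or still open, it means among the compounds named here.

Measured so far:
compound 1, `C[C@H](Nc1ncnc2[nH]cnc12)c1nn(-c2ccc(C#N)cc2)c2cc(F)ccc12`, 46%
compound 2, `C[C@H](Nc1ncnc2[nH]cnc12)c1nn(-c2ccccn2)c2cc(F)ccc12`, 12%
compound 3, `C[C@H](Nc1ncnc2[nH]cnc12)c1nn(-c2cc(F)cc(F)c2)c2cc(F)ccc12`, 14%

These three compounds share one core and differ only in the ring attached to an aromatic nitrogen. In a functional assay on Hep 3B2 cells (Homo sapiens) for inhibition, read by sulforhodamine B assay, with a stated time of 72 h, tested at 10 uM (a higher number here means more inhibition at the concentration tested (going by the name of the read-out), a lower number less inhibition), compound 1 gives the highest number of the three. Compound 3 stands second highest: its nearest neighbour is compound 2, with a number 2 percentage points higher from compound 2 to compound 3 (within the scatter), a gap within the scatter, while compound 1 lies far above it, as shown by a number 32 percentage points lower from compound 1 to compound 3 (beyond the scatter).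

Compound 4 is `C[C@H](Nc1ncnc2[nH]cnc12)c1nn(-c2ccncc2)c2cc(F)ccc12`. The change is pyridin-4-yl in place of 3,5-difluorophenyl on an aromatic nitrogen. Within the data shown here, the steps that bear on it are a number 34 percentage points lower from compound 1 to compound 2 (beyond the scatter) and a number 2 percentage points higher from compound 2 to compound 3 (within the scatter): a pyridin-2-yl ring and a 3,5-difluorophenyl ring gave compounds with numbers close to each other, both far below compound 1. A pyridin-4-yl ring resembles these more than the 4-cyanophenyl of compound 1, so no step beyond the scatter is expected in this assay. Compound 4 is therefore expected to give 15%, with a range from 4% to 30%. The estimated step of a number 1 percentage points higher from compound 3 to compound 4 (within the scatter) is expected to stay within the scatter.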

Compound 4, a percentage reported as inhibition, at one concentration (the size of the read-out at that concentration, not a potency): 5%
For compound 4 the middle estimate is 10 percentage points above the measured one; the measured number falls inside the stated range.
By their numbers in this assay, from the lowest: compounds 4, 2 and 3 (each within the scatter of the next); then compound 1.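

In this assay the two pyridine rings cannot be told apart, with a number 7 percentage points lower from compound 2 to compound 4 (within the scatter) on going from pyridin-2-yl to pyridin-4-yl. Replacing the carbon-only 3,5-difluorophenyl ring with a ring that contains a nitrogen also leaves the number within the scatter, with a number 9 percentage points lower from compound 3 to compound 4 (within the scatter) here. The 4-cyanophenyl ring alone stands apart, with a number 41 percentage points lower from compound 1 to compound 4 (beyond the scatter) as the large step, so among these four compounds the pyridin-2-yl, pyridin-4-yl and 3,5-difluorophenyl rings form one low group on this aromatic nitrogen.

As far as these compounds go, it stays open whether the nitrile itself carries the higher number, and what a phenyl ring bearing an amine or a carboxylic acid in its place would give. Nothing available explains why the 4-cyanophenyl ring stands apart from the other three.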